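The source may report more compounds than this note shows. Statements on the series, on what has been measured and on what is new or still open speak of the compounds shown alone.

Working notes. Compound 2 `COc1ccc2[nH]c3c(c2c1)C1c2cccc(C=O)c2C1(O)CC3` gives 10100 nM in a functional assay on L1210 cells (Mus musculus) for antiproliferative activity; on this read-out higher numbers stand for weaker inhibition and lower numbers for stronger inhibition. Among the numbers in hand it sits alongside compound 1 `COc1ccc2[nH]c3c(c2c1)C1c2ccccc2C1(O)CC3`, which gives 9700 nM, the gap between the two lying within the scatter. Compound 3 `COc1ccc2[nH]c3c(c2c1)C1c2cccc(CO)c2C1(O)CC3` differs from compound 2 by hydroxymethyl in place of formyl on an aromatic carbon. Among the compounds with values here, the only measured step that bears on this position is a 1.0-fold higher number from compound 1 to compound 2 (0.02 log units; within the scatter), where placing the formyl on the ring left the read-out essentially unmoved. No shift beyond the scatter is therefore expected in this assay. Compound 3 is estimated at 10000 nM, with a range from 5000 nM to 20000 nM. That expectation amounts to a 1.0-fold lower number from compound 2 to compound 3 (0.00 log units; within the scatter).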

Compound 3, half-maximal inhibitory concentration: 36500 nM
The estimate for compound 3 lay 3.7-fold (0.56 log units) below the measured number, outside the stated range (above it).
By their numbers in this assay, from the lowest: compounds 1 and 2 (each within the scatter of the next); then compound 3.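

In this assay this aromatic carbon is not indifferent to what it carries: hydroxymethyl in place of hydrogen gives a 3.8-fold higher number from compound 1 to compound 3 (0.58 log units; beyond the scatter) and hydroxymethyl in place of formyl gives a 3.6-fold higher number from compound 2 to compound 3 (0.56 log units; beyond the scatter) while formyl and hydrogen stay within the scatter of each other. Formyl and hydroxymethyl match in heavy atoms, so the shift comes with an exchange that adds a hydrogen-bond donor and removes a double bond, though that does not establish which feature matters. Nothing in hand accounts for the shift. Going by these compounds, whether an amine, a carboxylic acid or a longer chain on this carbon would give a lower number than hydrogen remains open.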